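A few compounds are considered here, and "the series" means these few. Any claim that something is new, unique, unknown or untested is made for them only; others in the source may bear on it.

Measured so far:
compound 1, `CNC(=O)[C@H]1O[C@@H](n2cnc3c(Nc4ccc5c(c4)C(C)(C)NC5(C)C)ncnc32)[C@H](O)[C@@H]1O`: 1170 nM
compound 2, `CC1(C)c2ccc(CNC3NC=Nc4c3ncn4[C@@H]3O[C@H](CO)[C@@H](O)[C@H]3O)cc2C(C)(C)N1[O]`: 1140 nM

In an assay on isolated protein for displacement of a labelled ligand from adenosine receptor A1 (Homo sapiens) (a lower number here means a stronger inhibitor, a higher number a weaker inhibitor), compound 1 gives 1170 nM, the higher of the two numbers measured, and compound 2 gives 1140 nM; the two lie within the scatter of each other, so no order can be read from them. Within the data shown here, compound 2 differs from compound 1 in several places at once, so no single step between the two is available.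

Compound 3, `CNC(=O)[C@H]1O[C@@H](n2cnc3c(Nc4ccc5c(c4)C(C)(C)N([O])C5(C)C)ncnc32)[C@H](O)[C@@H]1O`, is not yet measured. It differs from compound 1 by one oxygen atom in place of a hydrogen atom, on an amine nitrogen in a ring — one oxygen atom in place of a hydrogen atom, on an amine nitrogen in a ring. Compound 2 carries the same oxygen on its ring nitrogen and gives 1140 nM, which does not suggest a large shift from this group alone. The step of a 1.2-fold lower number from compound 1 to compound 3 (0.07 log units; within the scatter) is therefore expected to stay within the scatter, with no clear direction. For compound 3 the estimate is 1000 nM, within 400 nM to 2500 nM.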

Compound 3, inhibition constant: 800 nM
Compound 3: the middle estimate sits 1.3-fold (0.10 log units) above what was measured; measured number inside the range.
By their numbers in this assay, from the lowest: compounds 3, 2 and 1 (each within the scatter of the next).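

In this assay, the series now has its first step that differs in one place: a 1.5-fold lower number from compound 1 to compound 3 (0.17 log units; within the scatter). On the amine nitrogen in a ring, next to two ring atoms that each bear two methyl groups, one oxygen atom in place of a hydrogen atom therefore gives no change that can be read, and this rests on a direct pair rather than on the comparison with compound 2, which differs from compound 1 in several places at once. No measurement on hand bears on why this exchange leaves the number within the scatter.

The compounds shown leave open whether a methyl group or an acetyl group on the same nitrogen would also stay within the scatter. Also open, as far as these compounds go, is whether the same exchange gives a step of like size on the core of compound 2.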